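Compound 3 Gives Up Its Amino Group

The compounds below may be only part of what the source reports. "The series", "measured", "known", "first", "only" and "open" are said of these compounds alone.

In a functional assay on DU-145 cells (Homo sapiens) for cytotoxicity, read by trypan blue exclusion, with a stated time of 96 h (a higher number here means a weaker inhibitor, a lower number a stronger inhibitor), compound 1 (`COc1ccc(NS(=O)(=O)/C=C/c2c(F)c(F)c(F)c(F)c2F)cc1F`) gives 10000 nM and compound 2 (`COc1ccc(NS(=O)(=O)/C=C/c2c(F)c(F)c(F)c(F)c2F)cc1[N+](=O)[O-]`) gives 100000 nM while compound 3 (`COc1ccc(NS(=O)(=O)/C=C/c2c(F)c(F)c(F)c(F)c2F)cc1N`) gives 75000 nM on the same read-out. Nitro in place of fluoro is a 10-fold higher number from compound 1 to compound 2 (1.00 log units; beyond the scatter) and amino in place of fluoro is a 7.5-fold higher number from compound 1 to compound 3 (0.88 log units; beyond the scatter) in a similar range. Amino in place of nitro is a 1.3-fold lower number from compound 2 to compound 3 (0.12 log units; within the scatter) so compound 3 stands level with compound 2 and clearly above compound 1.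

Compound 4 (`COc1ccc(NS(=O)(=O)/C=C/c2c(F)c(F)c(F)c(F)c2F)cc1`) carries hydrogen in place of amino on an aromatic carbon. Among the compounds with values here, no measured compound has hydrogen on that carbon, so the evidence is indirect. Only compound 1, at 10000 nM with fluoro there, stands clear of the other two, so a modest fall toward its number is expected rather than no change. The estimated step is a 3.8-fold lower number from compound 3 to compound 4 (0.57 log units; beyond the scatter) toward a lower number, though this remains uncertain. Compound 4 is estimated at 20000 nM (expected range 6000 nM to 60000 nM).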

Compound 4, half-maximal inhibitory concentration: 10000 nM
Beside the measured number, compound 4's estimate is 2.0-fold (0.30 log units) above it; measured number inside the range.
By their numbers in this assay, from the lowest: compounds 1 and 4 (each within the scatter of the next); then compounds 3 and 2 (each within the scatter of the next).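

In this assay, replacing the amino or nitro group with hydrogen on this aromatic carbon gives a 7.5-fold lower number from compound 3 to compound 4 (0.88 log units; beyond the scatter) and a 10-fold lower number from compound 2 to compound 4 (1.00 log units; beyond the scatter), whereas replacing fluoro with hydrogen gives no change at the digits printed from compound 1 to compound 4 (within the scatter). The earlier compounds shown here showed only that amino and nitro carried higher numbers than fluoro; with hydrogen as the reference, the position now separates into two pairs, and fluoro offers no measurable gain over hydrogen, while amino and nitro both carry the higher numbers. No evidence is at hand to explain this separation.

On these data alone, it remains open whether a hydroxyl, a methyl or a carboxylic acid on this carbon would fall with hydrogen and fluoro or with amino and nitro. The same question stands for chloro, a small halogen beyond fluoro.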